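The compounds below may be only part of what the source reports. "The series", "measured", "known", "first", "only" and "open" are said of these compounds alone.

Measured compounds:
- compound 1, `CC(=O)/C(=C\c1ccccc1)Oc1ccccc1OCCCN1CCN(C)CC1`: 2.5 mg/kg
- compound 2, `CC(=O)/C(=C\c1ccccc1)Oc1ccccc1OCCCN(C)C`: 0.37 mg/kg

Both were tested in a functional assay on the whole organism (heart) with Rattus norvegicus as the target; a lower number here means that less compound is needed, a higher number that more compound is needed for the effect. For the measured compounds named here, compound 1 has the highest of the two numbers, so it needs the most compound for the effect; its nearest neighbour is compound 2, and the single measured step, a 6.8-fold lower number from compound 1 to compound 2 (0.83 log units; beyond the scatter), is beyond the scatter.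

Compound 3, `CC(=O)/C(=C\c1ccccc1)Oc1ccccc1OCCCN(C(C)C)C(C)C`, has not yet been measured in this assay. It differs from compound 1 in one place: diisopropylamino in place of 4-methylpiperazin-1-yl on a saturated chain carbon, three bonds along the chain from an oxygen on an aromatic ring.

Going by the values given here, the one step that bears on this change is a 6.8-fold lower number from compound 1 to compound 2 (0.83 log units; beyond the scatter), where an open-chain amine also took the place of the ring. Among the compounds with values here, that step is the only guide, and the diisopropylamino group is not the same as the dimethylamino group, so the estimate is wide. A lower number than compound 1 is expected for compound 3 in this assay, with an expected step of a 3.1-fold lower number from compound 1 to compound 3 (0.49 log units; beyond the scatter). Compound 3 is estimated at 0.8 mg/kg, within the range 0.3 mg/kg to 2.5 mg/kg.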

Compound 3, dose for half-maximal effect: 0.1 mg/kg
Compound 3: the middle estimate sits 8.0-fold (0.90 log units) above what was measured; the whole stated range lies above it.
By their numbers in this assay, from the lowest: compound 3; then compound 2; then compound 1.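

In this assay the open-chain amine at this place can be changed with a clear effect: going from dimethylamino to diisopropylamino gives a 3.7-fold lower number from compound 2 to compound 3 (0.57 log units; beyond the scatter) and so the earlier step from the ring to an open chain did not mark the end of what this position allows. Against the ring, the change gives a 25-fold lower number from compound 1 to compound 3 (1.40 log units; beyond the scatter) even though 4-methylpiperazin-1-yl and diisopropylamino have the same heavy-atom count, so that count alone does not set the dose needed here. Nothing measured explains why these groups differ.

The compounds shown do not separate the loss of the ring from the loss of its second nitrogen, which piperidin-1-yl would help to address. Diethylamino, which lies between the two open-chain amines in size, and a longer chain to the amine also remain open.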